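The source may hold more compounds than are shown below. What is called first, only, known or untested is meant among the compounds shown, and "the series" means these compounds.

Series notes. Compound 1 `CN1C(=S)[C@@H](NC(=O)c2nc(Cc3ccccc3)n(C)n2)COc2ccccc21` carries hydrogen on the saturated chain carbon bound to the aromatic nitrogen; in a functional assay on HT-29 cells (Homo sapiens) for inhibition, read by luminescence and CellTiter-Glo, with a stated time of 24 h (on this read-out lower numbers stand for an effect already at smaller amounts and higher numbers for an effect only at larger amounts of compound), compound 1 gives 2.5 nM. Compound 2 `CCCCn1nc(C(=O)N[C@H]2COc3ccccc3N(C)C2=S)nc1Cc1ccccc1` carries propyl at that place and gives 510 nM, while compound 3 `CN1C(=S)[C@@H](NC(=O)c2nc(Cc3ccccc3)n(CCCC#N)n2)COc2ccccc21` carries 2-cyanoethyl there and gives 2400 nM. Both substitutions move the number upward by large steps, a 200-fold higher number from compound 1 to compound 2 (2.31 log units; beyond the scatter) and a 960-fold higher number from compound 1 to compound 3 (2.98 log units; beyond the scatter), and between the two substituted compounds the step is a 4.7-fold higher number from compound 2 to compound 3 (0.67 log units; beyond the scatter). Compound 3 therefore stands highest of the three numbers, with compound 2 nearest and compound 1 furthest away.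

Compound 4 `CN1C(=S)[C@@H](NC(=O)c2nc(Cc3ccccc3)n(CC3CCOCC3)n2)COc2ccccc21` differs from compound 3 by oxan-4-yl in place of 2-cyanoethyl on a saturated chain carbon bound to an aromatic nitrogen. The measured steps that bear on this are the two departures from hydrogen, both large and upward, and the modest upward step from propyl to 2-cyanoethyl. Among the measured compounds shown here, no measured compound carries a ring at this place, so the comparison rests on analogy: oxan-4-yl is another substituent at the same place, one without the nitrile. For compound 4 a modest downward step is expected, a 3.0-fold lower number from compound 3 to compound 4 (0.48 log units; beyond the scatter). In this assay compound 4 is expected to give about 800 nM, within the range 150 nM to 4000 nM.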

Compound 4, half-maximal effective concentration: 6310 nM
Compound 4: the middle estimate sits 7.9-fold (0.90 log units) below what was measured; measured number above the stated range.
By their numbers in this assay, from the lowest: compound 1; then compound 2; then compound 3; then compound 4.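

In this assay the exchange of 2-cyanoethyl for oxan-4-yl gives a 2.6-fold higher number from compound 3 to compound 4 (0.42 log units; beyond the scatter) and so does not bring the number back toward that of compound 1; the high number of compound 3 is therefore not tied to the nitrile alone, since compound 4 carries no nitrile and still stands higher. Measured against the other two compounds, oxan-4-yl gives a 12-fold higher number from compound 2 to compound 4 (1.09 log units; beyond the scatter) and a 2500-fold higher number from compound 1 to compound 4 (3.40 log units; beyond the scatter) and thereby extends the pattern at this place: all three substituents on the saturated chain carbon bound to an aromatic nitrogen, whether open chain, nitrile-bearing or ring-bearing, stand far above compound 1, and none of the four compounds goes against this. Nothing at hand gives a reason for this order.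

Still open, going by these compounds, is whether a shorter group such as ethyl at this place keeps part of the low number of compound 1, or whether the large rise already appears with the first added carbon. Also open, on these data alone, is whether a cyclohexyl ring, without the ring oxygen, or a chain ending in an amine or a carboxylic acid would follow the same upward course.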